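A fluoro substituent added to the aniline ring of compound 2

This account rests on a few compounds, and the source may have more. Where it says the series, first, only, none or still open, it means among the compounds named here.

Of the compounds shown here, two share a core and have been measured in a functional assay for inhibition, with Homo sapiens as the target; on this read-out higher numbers stand for weaker inhibition and lower numbers for stronger inhibition. Compound 1 `Fc1cccc(Nc2nccc(-c3ccccn3)n2)c1` carries a fluoro substituent on its aniline ring, and in this assay compound 1 gives 1000 nM. Compound 2 `c1ccc(Nc2nccc(-c3ccncc3)n2)cc1` lacks that substituent, and in this assay compound 2 gives 900 nM; the two numbers lie within the usual scatter of each other, so neither can be called the stronger inhibitor on this evidence. Compound 3 `Fc1cccc(Nc2nccc(-c3ccncc3)n2)c1` is the next compound and has not yet been measured. It differs from compound 2 by fluoro in place of hydrogen on an aromatic carbon. Going by the values given here, no measured pair isolates this change, so the expectation rests on compound 1 and compound 2 alone, whose values sit close together. Compound 3 is therefore expected to show a step from compound 2 of no change at the digits printed from compound 2 to compound 3 (within the scatter), that is, nothing beyond the scatter in either direction. Compound 3 is estimated at 900 nM, with a likely range from 400 nM to 2000 nM.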

Compound 3, half-maximal inhibitory concentration: 700 nM
The estimate for compound 3 lay 1.3-fold (0.11 log units) above the measured number, and the stated range covers the measured number.
By their numbers in this assay, from the lowest: compounds 3, 2 and 1 (each within the scatter of the next).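

In this assay, the change from hydrogen to fluoro now stands on its own in a single pair (a 1.3-fold lower number from compound 2 to compound 3 (0.11 log units; within the scatter)), and at this place, meta to a large group, it cannot be told from the scatter. With the fluoro group held constant, pyridin-4-yl in place of pyridin-2-yl can now be read as well (a 1.4-fold lower number from compound 1 to compound 3 (0.15 log units; within the scatter)), and this step also stays inside the scatter. Nothing measured here bears on this result.

The compounds shown leave open whether a larger or charged group at this place, such as a methoxy group, an amine or a carboxylic acid, would move the number beyond the scatter. They also leave open how pyridin-3-yl would compare with the two pyridinyl groups shown.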